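A few compounds are considered here, and "the series" means these few. Any claim that something is new, unique, unknown or untested is made for them only; others in the source may bear on it.

Compound 1 `c1ccc(-c2nn(-c3ccccc3)cc2-c2nc3ccccc3[nH]2)cc1` is the unsubstituted parent of this small set, and in a functional assay on MCF7 cells (Homo sapiens) for antiproliferative activity, read by MTT assay, with a stated time of 48 h (on this read-out lower numbers stand for stronger inhibition and higher numbers for weaker inhibition), compound 1 gives 3190 nM. Compound 2 `Brc1ccc2[nH]c(-c3cn(-c4ccccc4)nc3-c3ccccc3)nc2c1` carries bromo in place of hydrogen on an aromatic carbon, and in this assay compound 2 gives 830 nM. For the measured compounds named here, the one measured step, a 3.8-fold lower number from compound 1 to compound 2 (0.58 log units; beyond the scatter), is modest but beyond the scatter, so compound 2 stands with the lowest of the two numbers, and compound 1 is the only other compound, lying above it by more than the scatter.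

Compound 3 `FC(F)(F)c1ccc2[nH]c(-c3cn(-c4ccccc4)nc3-c3ccccc3)nc2c1` differs from compound 2 by trifluoromethyl in place of bromo on an aromatic carbon. Going by the values given here, no measured step exchanges bromo for trifluoromethyl, so the only step that bears on this change is a 3.8-fold lower number from compound 1 to compound 2 (0.58 log units; beyond the scatter), which shows that a group at this carbon lowers the number relative to the bare compound 1. Because a 3.8-fold lower number from compound 1 to compound 2 (0.58 log units; beyond the scatter) was itself only modest, the step of a 1.1-fold higher number from compound 2 to compound 3 (0.04 log units; within the scatter) is expected to lie within the scatter, in no firm direction. Compound 3 is therefore estimated at 900 nM, with a range from 400 nM to 2000 nM.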

Compound 3, half-maximal inhibitory concentration: 2660 nM
Compound 3: the middle estimate sits 3.0-fold (0.47 log units) below what was measured, and the stated range ends below it.
By their numbers in this assay, from the lowest: compound 2; then compounds 3 and 1 (each within the scatter of the next).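

At this aromatic carbon, what counts is which group is present and not merely that one is present: in this assay the exchange of bromo for trifluoromethyl gives a 3.2-fold higher number from compound 2 to compound 3 (0.51 log units; beyond the scatter) and so takes back most of the gain that bromo had brought. Set against the unsubstituted parent, trifluoromethyl gives a 1.2-fold lower number from compound 1 to compound 3 (0.08 log units; within the scatter) and leaves compound 3 indistinguishable from compound 1, so compound 2 alone stands apart from the parent, and compound 3 goes against any reading that a group at this carbon lowers the number by its presence alone. Nothing at hand accounts for why bromo and trifluoromethyl part in this way.

The compounds shown leave open how other groups would fare at this carbon, such as a chlorine atom, a methoxy group, a nitrile or an amine, and so whether bromo is a single favourable case or one of several. They also leave open whether the gap between bromo and trifluoromethyl would persist with either group placed elsewhere on the shared core.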